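Diethylamino-Hydroxyphenyl in Place of Fluorophenyl on the Hydrazone

The source may hold more compounds than are shown below. What is called first, only, known or untested is meant among the compounds shown, and "the series" means these compounds.

Of the compounds shown here, three have been tested in a functional assay on HepG2 cells (Homo sapiens) for cytotoxicity, read by MTT assay, with a stated time of 72 h; on this read-out higher numbers stand for weaker inhibition and lower numbers for stronger inhibition. Compound 1 `O=C(N/N=C/c1ccc(F)cc1)Nc1cc2c(Nc3ccc(F)c(Cl)c3)ncnc2cc1O[C@H]1CCOC1` gives "not active" (no number reported) in this assay, with no number reported. Compound 2 `COc1ccc(/C=N/NC(=O)Nc2cc3c(Nc4ccc(F)c(Cl)c4)ncnc3cc2O[C@H]2CCOC2)c(OC)c1OC` gives 29300 nM in this assay. Compound 3 `COc1cc2ncnc(Nc3ccc(F)c(Cl)c3)c2cc1NC(=O)N/N=C/c1ccc(F)cc1` gives 31100 nM in this assay, the higher of the two numbers, yet compound 2 sits so close that the two fall within the usual scatter, and no order between them can be read from these values.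

The next compound, compound 4 `CCN(CC)c1ccc(/C=N/NC(=O)Nc2cc3c(Nc4ccc(F)c(Cl)c4)ncnc3cc2OC)c(O)c1`, has not been measured in this assay. It differs from compound 3 in one place: 4-(diethylamino)-2-hydroxyphenyl in place of 4-fluorophenyl on a carbon with a double bond to nitrogen The 4-(diethylamino)-2-hydroxyphenyl enters on the carbon with a double bond to nitrogen where the 4-fluorophenyl stood. No measured pair in the set shares this change, so the size of the step cannot be drawn from a shown step. The two numbers available sit close together and compound 1 gave no number at all. On that basis a step of a 1.6-fold lower number from compound 3 to compound 4 (0.19 log units; within the scatter) is expected, small and perhaps toward a lower number, though possibly none beyond the scatter. Compound 4 is expected to give 20000 nM in this assay, within a range from 6000 nM to 60000 nM.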

Compound 4, half-maximal inhibitory concentration: 29300 nM
Estimate against measurement, compound 4: 1.5-fold (0.17 log units) below; low and high end bracket the measured number.
By their numbers in this assay, from the lowest: compounds 2, 4 and 3 (each within the scatter of the next).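

Until now no measured pair had shown a step at this carbon with a double bond to nitrogen, and in this assay the exchange of 4-fluorophenyl for 4-(diethylamino)-2-hydroxyphenyl gives a 1.1-fold lower number from compound 3 to compound 4 (0.03 log units; within the scatter) as its first such step. The entering group brings 12 heavy atoms where the leaving group had 7, and 1 hydrogen-bond donor and 2 hydrogen-bond acceptors where the leaving group had none, yet compound 3 and compound 4 cannot be told apart on this read-out, so this position accepts the larger, substituted aryl group with no difference that can be read. No measurement in hand bears on why the two compounds stand so close.

The compounds shown carry the diethylamino and hydroxy groups only together on one ring, so they leave open what either group would do alone at this carbon. They also leave open whether a different kind of group here, such as a phenyl ring bearing a carboxylic acid or a morpholine, would give a number beyond the scatter of compound 3.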